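Swapping Chloro for Bromo: What to Expect

The compounds below may be only part of what the source reports. "The series", "measured", "known", "first", "only" and "open" are said of these compounds alone.

Going by the values given here, compound 2 `Cn1nnnc1SCC(=O)N/N=C/c1ccc(Cl)cc1` stands lowest of the two numbers so far in an ADME assay on NIH3T3 cells (Mus musculus) for cytotoxicity, read by XTT assay, with a stated time of 24 h; on this read-out lower numbers stand for stronger inhibition and higher numbers for weaker inhibition: compound 2 gives 2100000 nM. Compound 1 `Cn1nnnc1SCC(=O)N/N=C/c1ccc([N+](=O)[O-])cc1` gives 9300000 nM, and the step of a 4.4-fold lower number from compound 1 to compound 2 (0.65 log units; beyond the scatter) replaced nitro with chloro on an aromatic carbon. Compound 3 `Cn1nnnc1SCC(=O)N/N=C/c1ccc(Br)cc1` differs from compound 2 by bromo in place of chloro on an aromatic carbon, para to a large group. Among the compounds with values here, no measured step exchanges one halogen for another; the single step only shows chloro giving a lower number than nitro at that place. A small drop, or no change beyond the scatter, is therefore expected: a 1.3-fold lower number from compound 2 to compound 3 (0.12 log units; within the scatter). Compound 3 is estimated at 1600000 nM, within 600000 nM to 4500000 nM.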

Compound 3, half-maximal inhibitory concentration: 10000000 nM
For compound 3 the middle estimate is 6.3-fold (0.80 log units) below the measured one; the whole stated range lies below it.
By their numbers in this assay, from the lowest: compound 2; then compounds 1 and 3 (each within the scatter of the next).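

In this assay, this position distinguishes between two halogens: the swap gives a 4.8-fold higher number from compound 2 to compound 3 (0.68 log units; beyond the scatter), so bromo cannot be treated as a stand-in for chloro here. Bromo and nitro do not separate, with a 1.1-fold higher number from compound 1 to compound 3 (0.03 log units; within the scatter), which leaves chloro alone at the low end of these compounds. No measurement at hand accounts for the gap between the two halogens.

Going by these compounds, what fluoro, an amine or a carboxylic acid would give at this place remains open. Three compounds on one shared core support no general trend.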